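Swapping the pyrimidine amide of compound 1 for an imidazole

This account rests on a few compounds, and the source may have more. Where it says the series, first, only, none or still open, it means among the compounds named here.

compound 1 `O=C(NCc1ccc(CNS(=O)(=O)c2ccc(F)cc2F)cc1)c1cncnc1`: 1 nM
compound 2 `O=C(NCc1ccc(CNS(=O)(=O)c2ccc(F)c(F)c2)cc1)c1cnc2ccccn12`: > 1000 nM
compound 3 `Cn1nccc1C(=O)NCc1ccc(CNS(=O)(=O)c2ccc3c(c2)CCO3)cc1`: 1000 nM

In an assay on cells for displacement of a labelled ligand from C-X-C chemokine receptor type 4 (Homo sapiens), read by fluorescence and microscopy, with stated times of 10 min and 30 min (a lower number here means that less compound is needed, a higher number that more compound is needed for the effect), compound 1 gives 1 nM, the lowest of the two numbers. Compound 3 gives 1000 nM, a gap beyond the scatter. Compound 2 reaches only a limit of the assay, > 1000 nM (the limit of > 1000 nM in this assay, at which 1 of the 3 values shown sits). Among the measured compounds shown here, compounds 2 and 3 differ from compound 1 in more than one place, so no single step isolates the amide heteroaryl. Compound 4 `O=C(NCc1ccc(CNS(=O)(=O)c2ccc(F)cc2F)cc1)c1ncc[nH]1` differs from compound 1 in one place: 1H-imidazol-2-yl in place of pyrimidin-5-yl on a carbonyl carbon. A modest loss is expected, an 8.0-fold higher number from compound 1 to compound 4 (0.90 log units; beyond the scatter), since the shared core is kept and only the amide heteroaryl changes. Compound 4 is estimated at 8 nM, between 1 nM and 80 nM.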

Compound 4, effective concentration (reported as EC, without a stated level of effect): > 1000 nM
Compound 4 was reported as a limit; the forecaster's own chance of this, stated with the estimate: 5%; at least 120-fold (2.09 log units) between middle value and limit.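

In this assay, this one change on the carbonyl carbon gives an at least 1000-fold higher number from compound 1 to compound 4 (3.00 log units; beyond the scatter). With the rest of compound 1 kept, the amide heteroaryl alone can decide the result, which compounds 2 and 3 could not show. Compound 4 is a limit, not a number, so the full size of the loss stays unknown: the limit of > 1000 nM in this assay, at which 2 of the 4 values shown sit.

Ring size and the hydrogen-bond donor count change together in this step, and the compounds shown do not separate them. From the compounds shown here alone, how a phenyl or pyridin-3-yl ring would fare in this place also stays open.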